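Replacing the Hydroxy Group of Compound 2

The compounds below may be only part of what the source reports. "The series", "measured", "known", "first", "only" and "open" are said of these compounds alone.

Measured compounds:
- Compound 1 `CO[C@H]1CC[C@H](NC(=O)c2n[nH]cc2NC(=O)c2cnc3ccccn23)CC1` gives 5900 nM in an ADME assay on MRC5 cells (Homo sapiens) for inhibition, with a stated time of 72 h; a lower number here means that less compound is needed, a higher number that more compound is needed for the effect.
- Compound 3 `CO[C@H]1CC[C@H](NC(=O)c2n[nH]cc2NC(=O)c2ccc(OC(F)F)cc2)CC1` gives 2500 nM in this assay.
- Compound 2 `COc1cccc(OC)c1C(=O)Nc1c[nH]nc1C(=O)O` reaches only the limit of > 50000 nM in this assay, not a number.

Compound 2 therefore stands apart from the two numbers shown: where compound 1 and compound 3 each give a measured value, compound 2 sits at the limit of > 50000 nM in this assay, at which 1 of the 3 values shown sits, and nothing more precise is known about it.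

Compound 4 `COc1cccc(OC)c1C(=O)Nc1c[nH]nc1C(=O)NCCN1CCCC1` is the untested partner of compound 2. The change is (2-(pyrrolidin-1-yl)ethyl)amino in place of hydroxy on a carbonyl carbon. The shared core of compound 2 and compound 4 is kept unchanged; only the group on that carbonyl carbon differs.

For the measured compounds named here, no step between two measured compounds in this assay is available to calibrate this change, so the expectation rests on the spread of the three values. Compound 1 and compound 3 show that amides built on a related core can give measured numbers in this assay, whereas compound 2, with its hydroxy group, gives only a limit. Compound 4 is expected to move toward the measured range, with a step of an at least 2.5-fold lower number from compound 2 to compound 4 (0.39 log units; beyond the scatter), although this may again end at a limit.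

Compound 4 is estimated at 20000 nM, in the range 5000 nM to 50000 nM.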

Compound 4, half-maximal effective concentration: > 50000 nM
Compound 4: no number, only a limit; the forecaster's own chance of this, stated with the estimate: 40%; middle value at least 2.5-fold (0.39 log units) away from the limit.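

In this assay compound 4 gives only a limit, > 50000 nM, not a number. For the compounds shown here, compound 2 sits at the same limit, so no step from compound 2 to compound 4 can be read: the limit of > 50000 nM in this assay, at which 2 of the 4 values shown sit. The compounds shown leave open whether (2-(pyrrolidin-1-yl)ethyl)amino in place of hydroxy on a carbonyl carbon changes the value in this assay at all.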